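Swapping chloro for fluoro in a shared core

The compounds below may be only part of what the source reports. "The series", "measured", "known", "first", "only" and "open" are said of these compounds alone.

Compound 1 `O[C@@H]1Cc2ccccc2N[C@H](c2ccc(Cl)cc2)C1` gives 114000 nM in an ADME assay on THP-1 cells (Homo sapiens) for cytotoxicity, read by MTT assay, with a stated time of 72 h; on this read-out lower numbers stand for higher toxicity in this test and higher numbers for lower toxicity in this test.
Compound 2 `O[C@@H]1Cc2ccccc2N[C@H](c2ccc(F)cc2)C1` reaches only a limit of this assay, > 300000 nM.
Compound 3 `O[C@@H]1Cc2cc(Cl)ccc2N[C@H](c2c(Cl)cccc2Cl)C1` gives 59600 nM in this assay.

Compound 1 and compound 2 differ by fluoro in place of chloro on an aromatic carbon, a change that made an at least 2.6-fold higher number from compound 1 to compound 2 (0.42 log units; beyond the scatter). The reading for compound 2 is a limit and not a number (the limit of > 300000 nM in this assay, at which 1 of the 3 values shown sits). Compound 3 carries a different core; how the two cores differ is not broken down here, and its value and that of compound 1 lie within the usual scatter of each other.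

Compound 4 `O[C@@H]1Cc2cc(Cl)ccc2N[C@H](c2c(F)cccc2Cl)C1` is not yet measured. It differs from compound 3 by fluoro in place of chloro on an aromatic carbon. This is the same kind of change as before, but here the place is ortho to a large group and meta to a chloro group, rather than para to a large group. A step in the same direction is expected, a 2.5-fold higher number from compound 3 to compound 4 (0.40 log units; beyond the scatter), because the earlier change made an at least 2.6-fold higher number from compound 1 to compound 2 (0.42 log units; beyond the scatter). Compound 4 is accordingly estimated at 150000 nM.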

Compound 4, half-maximal cytotoxic concentration: 110000 nM
Compound 4: the middle estimate sits 1.4-fold (0.13 log units) above what was measured; low and high end bracket the measured number.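

In this assay, fluoro in place of chloro on the core of compound 3 gives a 1.8-fold higher number from compound 3 to compound 4 (0.27 log units; within the scatter), so this step alone cannot be told apart from ordinary variation between repeat measurements. It therefore neither confirms that the earlier effect carries over to this core nor shows that it fails to, and the two steps cannot be separated: the same change on two cores in this assay, an at least 2.6-fold higher number (0.42 log units; beyond the scatter) from compound 1 to compound 2 and a 1.8-fold higher number (0.27 log units; within the scatter) from compound 3 to compound 4; the limit leaves it open whether they differ. The reading for compound 2 is a limit of the assay and not a number: the limit of > 300000 nM in this assay, at which 1 of the 4 values shown sits.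

The compounds shown leave open whether the swap would act alike at other places on this ring. They also cannot tell how an amine or a methoxy group would compare with these two halogens.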